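Ethyl on the amide nitrogen of a hydroxamic acid

The source may hold more compounds than are shown below. What is called first, only, known or untested is meant among the compounds shown, and "the series" means these compounds.

Measured compounds:
Compound 1 `CC(C)c1cc(C(=O)Nc2ccc(NC(=O)CCCCCCC(=O)NO)cc2)c(O)cc1O`: in a functional assay on A549 cells (Homo sapiens) for inhibition, read by sulforhodamine B assay, with a stated time of 48 h (on this read-out higher numbers stand for weaker inhibition of growth and lower numbers for stronger inhibition of growth), compound 1 gives > 10000 nM, which is a limit of the assay and not a number.
Compound 2 `CC(C)c1cc(C(=O)Nc2ccccc2NC(=O)CCCCCCC(=O)NO)c(O)cc1O`: in this assay compound 2 gives > 10000 nM, also a limit rather than a number.

Both compounds carry the same long chain ending in a hydroxamic acid and the same shared core; they differ only in how the two amide groups are arranged on the middle part of the molecule. On the numbers shown, compound 1 stands only at a limit, and the one other value shown is a limit as well (the limit of > 10000 nM in this assay, at which 2 of the 2 values shown sit). Going by the values given here, no step between measured compounds is available, so nothing yet shows how any change moves this read-out.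

Compound 3 `CCN(C(=O)c1cc(C(C)C)c(O)cc1O)c1ccc(NC(=O)CCCCCCC(=O)NO)cc1` is not yet measured. (ethyl in place of hydrogen on an amide-type nitrogen). For this step in this assay no movement beyond the scatter is expected, and the result is expected most likely to be reported again as a limit. For compound 3 the estimated value is 15000 nM, with an expected range from 4000 nM to 50000 nM. The step this estimate implies is a step that the limit leaves unreadable from compound 1 to compound 3.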

Compound 3, concentration for 50% growth inhibition: 5630 nM
Estimate against measurement, compound 3: 2.7-fold (0.43 log units) above; the measured number falls inside the stated range.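

In this assay, ethyl in place of hydrogen on the amide-type nitrogen gives an at least 1.7-fold lower number from compound 1 to compound 3 (0.24 log units; that floor lies within the scatter). Compound 3 is the only compound shown that gives a real number rather than a limit, so this nitrogen can carry ethyl instead of the amide hydrogen with growth inhibition still inside the measurable range. The full size of the step cannot be read, and the floor alone does not establish a change beyond the scatter, because the starting point is only a limit, like most of the values here: the limit of > 10000 nM in this assay, at which 2 of the 3 values shown sit.

Going by these compounds, whether methyl or a longer chain such as propyl on this nitrogen would lower the number further remains open. On these data alone, it is also open whether ethyl on the matching nitrogen of compound 2 would bring that compound into the measurable range.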